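The source may hold more compounds than are shown below. What is called first, only, known or untested is meant among the compounds shown, and "the series" means these compounds.

Measured in an ADME assay on a cell-free system (plasma, Homo sapiens) for metabolic stability, read by LC-MS; on this read-out higher numbers stand for a longer-lived compound and lower numbers for a shorter-lived compound:
Compound 1 `COc1cc(/C=C/C(=O)O[C@H]2CC[C@@H](N(C)CCCOC(=O)c3cc(OC)c(OC)c(OC)c3)CC2)cc(OC)c1OC`: >= 4 h
Compound 2 `COc1cc(/C=C/C(=O)OCCCN(C)[C@H]2CC[C@H](OC(=O)c3cc(OC)c(OC)c(OC)c3)CC2)cc(OC)c1OC`: <= 2 h
Compound 3 `COc1cc(/C=C/C(=O)O[C@H]2CC[C@@H](N(C)CCCCCOC(=O)c3cc(OC)c(OC)c(OC)c3)CC2)cc(OC)c1OC`: >= 4 h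

All three values are limits of the assay, not exact numbers. Compound 3 stands at the limit of >= 4 h in this assay, at which 2 of the 3 values shown sit. Compound 2 stands at the limit of <= 2 h in this assay, at which 1 of the 3 values shown sits.

Compound 4 `COc1cc(/C=C/C(=O)O[C@H]2CC[C@H](N(C)CCCCCOC(=O)c3cc(OC)c(OC)c(OC)c3)CC2)cc(OC)c1OC` has the same atoms and bonds as compound 3 and differs only in configuration as drawn: the two compounds have the same atoms and bonds and differ only in configuration as drawn: 2 of 3 stereo elements differ; a stereocentre at a saturated ring carbon is drawn s in compound 3 and r in compound 4; a stereocentre at a saturated ring carbon is drawn s in compound 3 and r in compound 4. Going by the values given here, no measured pair shows the size of such a change. The closest guide is compound 3, at >= 4 h, which is only a limit. In this assay, no step beyond the usual scatter is expected, and neither direction is favoured. The estimated step is a number no higher from compound 3 to compound 4 (the limit leaves the size open). The estimated half-life for compound 4 is 4 h, with an expected range of 1.5 h to 8 h.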

Compound 4, half-life: >= 4 h
Compound 4 ended at the assay's limit; the forecaster's own chance of this, stated with the estimate: 75%; the middle value sits exactly at the limit.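

Compound 3 and compound 4 both give a limit rather than an exact number, so no step between them can be read: the limit of >= 4 h in this assay, at which 3 of the 4 values shown sit.

From the compounds shown here alone, whether the difference in configuration changes the half-life at all remains open.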